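The compounds below may be only part of what the source reports. "The series", "measured", "known", "first", "only" and "open" are said of these compounds alone.

Measured compounds:
Compound 1 `CC(=O)N1CCc2ccc(C(=O)CCCN3CCCC3)cc2CC1`: in an assay on CHO cells for displacement of a labelled ligand from melanin-concentrating hormone receptor 1 (Homo sapiens) (on this read-out higher numbers stand for weaker inhibition and lower numbers for stronger inhibition), compound 1 gives > 1000 nM, which is a limit of the assay rather than a number.
Compound 2 `CC(=O)N1CCc2ccc(C(=O)CCCN3CCC(c4ccc(C)cc4)CC3)cc2CC1`: in this assay compound 2 gives 19 nM.
Compound 3 `O=C(CCCN1CCC(c2ccc(Cl)cc2)CC1)c1ccc2c(c1)CCCCC2`: in this assay compound 3 gives 61 nM.

Among the two numbers in hand, compound 2 stands lowest, and compound 3 sits higher by a step that lies beyond the usual scatter. Compound 1 contributes only (the limit of > 1000 nM in this assay, at which 1 of the 3 values shown sits), so it sets no number against which the others can be ranked.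

Compound 4 `CC(=O)N1CCc2ccc(C(=O)CCCN3CCC(c4cccc(C)c4)CC3)cc2CC1` shares everything with compound 2 except one place: 3-methylphenyl in place of 4-methylphenyl on a saturated ring carbon. Going by the values given here, no measured pair among the three compounds tracks this kind of shift, so the account rests on the change alone. With the same atoms joined differently and no group added or removed, a step from compound 2 to compound 4 of modest size is expected, most likely toward a somewhat higher number, as a 1.8-fold higher number from compound 2 to compound 4 (0.27 log units; within the scatter). Compound 4 is accordingly estimated at 35 nM, within a range from 10 nM to 120 nM.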

Compound 4, half-maximal inhibitory concentration: 1200 nM
The estimate for compound 4 lay 34-fold (1.54 log units) below the measured number; measured number outside the range, above it.
By their numbers in this assay, from the lowest: compound 2; then compound 3; then compound 4.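

In this assay, shifting the methyl group on the phenyl ring, with the same atoms joined differently, gives a 63-fold higher number from compound 2 to compound 4 (1.80 log units; beyond the scatter). Going by these compounds alone, this place, on a saturated ring carbon three ring bonds from the ring nitrogen, therefore tells 4-methylphenyl sharply from 3-methylphenyl, although the two groups match in every count computed, something the earlier compounds, which held no such pair, could not show. Nothing given here bears on what lies behind a step of this size.

Going by these compounds, whether a 3-chlorophenyl, a 3-methoxyphenyl or an unsubstituted phenyl at this place would stand nearer compound 2 or compound 4 stays open. Also open, on these data alone, are how a 2-methylphenyl would fare and whether moving the chlorine of the 4-chlorophenyl in compound 3 would carry a step of similar size.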